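This account rests on a few compounds, and the source may have more. Where it says the series, first, only, none or still open, it means among the compounds named here.

Measured compounds:
compound 1 `CC(C)(C)c1ccc(CN2C(=O)S/C(=C\c3cccc(N)c3)C2=O)cc1`, 165000 nM
compound 2 `Nc1cccc(/C=C2\SC(=O)N(Cc3ccccc3)C2=O)c1`, > 250000 nM

Compound 2, in a functional assay on CCRF-CEM cells (Homo sapiens) for cytotoxicity, read by cell counting, with a stated time of 3 days (on this read-out higher numbers stand for weaker inhibition and lower numbers for stronger inhibition), gives only a limit, > 250000 nM. Compound 1, the tert-butyl analogue, gives 165000 nM in this assay. Within the data shown here, the single measured step, an at least 1.5-fold higher number from compound 1 to compound 2 (0.18 log units; that floor lies within the scatter), rests on that limit (the limit of > 250000 nM in this assay, at which 1 of the 2 values shown sits), so its true size stays open. Compound 3 `Nc1cccc(/C=C2\SC(=O)N(Cc3ccc(C(F)(F)F)cc3)C2=O)c1` carries trifluoromethyl in place of hydrogen on an aromatic carbon. Among the measured compounds shown here, the only step that bears on it is the one from compound 1 to compound 2, where replacing tert-butyl by hydrogen left compound 2 at its limit; compound 3 again places a group on that aromatic carbon. Compound 3 is therefore expected to return roughly to where compound 1 stands, a step of about an at least 1.3-fold lower number from compound 2 to compound 3 (0.14 log units; that floor lies within the scatter) in this assay. The estimate for compound 3 is 180000 nM, with a range from 90000 nM to 400000 nM.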

Compound 3, half-maximal inhibitory concentration: > 250000 nM
Compound 3 gave a limit, no number; the forecaster's own chance of this, stated with the estimate: 40%; middle value at least 1.3-fold (0.14 log units) away from the limit.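

In this assay compound 3 gives only a limit, > 250000 nM. Trifluoromethyl in place of tert-butyl gives an at least 1.5-fold higher number from compound 1 to compound 3 (0.18 log units; that floor lies within the scatter), so a group on this aromatic carbon, para to a large group, does not by itself yield a measured number: of the two groups shown there, only tert-butyl in compound 1 does. The step from hydrogen to trifluoromethyl cannot be read, as both of its ends are limits, and most of the series now gives no number to compare:  the limit of > 250000 nM in this assay, at which 2 of the 3 values shown sit.

As far as these compounds go, whether a longer alkyl chain, a methoxy group or a carboxylic acid on this aromatic carbon would give a number clearly lower than that of compound 1 stays open. Also open, from the compounds shown here alone, are the true values of compound 2 and compound 3, and whether these two differ at all.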